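The compounds below may be only part of what the source reports. "The series", "measured", "known", "first", "only" and "open" are said of these compounds alone.

In a functional assay on K562 cells (Homo sapiens) for antiproliferative activity, read by sulforhodamine B assay, with a stated time of 72 h (on this read-out lower numbers stand for stronger inhibition and higher numbers for weaker inhibition), compound 2 (`Cc1cc(C)nc(NS(=O)(=O)c2ccc(Nc3nncc4ccccc34)cc2)n1`) gives 4.9 nM. Compound 3 (`Clc1ccc(C(/C=C/c2ccccc2)=N\Nc2nncc3ccccc23)cc1`) gives 6.9 nM, which lies within the usual scatter of the value for compound 2, so the two cannot be ranked against each other. Compound 1 (`CCN1C(=O)CS/C1=N/Nc1nncc2ccccc12`) gives 76 nM, and its gap to compound 2 is well beyond the scatter. Compound 2 therefore stands among the two low numbers in this small set.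

Compound 4 (`Cc1cc(NS(=O)(=O)c2ccc(Nc3nncc4ccccc34)cc2)no1`) has not yet been measured. It keeps the whole of compound 2 except for one group: 5-methyl-1,2-oxazol-3-yl in place of 4,6-dimethylpyrimidin-2-yl on a sulfonamide nitrogen. Put simply, 5-methyl-1,2-oxazol-3-yl takes the place of 4,6-dimethylpyrimidin-2-yl on a sulfonamide nitrogen, so a five-membered aromatic ring replaces a six-membered one.

Within the data shown here, no two measured compounds differ in just one place, so the data offer no direct guide to the size of this swap. The expectation must instead start from compound 2 at 4.9 nM, since the rest of the structure stays the same. The expected change is modest, a 1.8-fold higher number from compound 2 to compound 4 (0.26 log units; within the scatter), most likely towards a slightly higher number and not far beyond the scatter. For compound 4 the estimated value is 9 nM, with an expected range from 2.5 nM to 35 nM.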

Compound 4, half-maximal inhibitory concentration: 23 nM
Compound 4: the middle estimate sits 2.6-fold (0.41 log units) below what was measured, within the range that was stated.
By their numbers in this assay, from the lowest: compounds 2 and 3 (each within the scatter of the next); then compound 4; then compound 1.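

Among these compounds, this is the first pair in the set that differs in one place only, so the group on the sulfonamide nitrogen can now be judged on its own in this assay and the size of the exchange can be read directly (a 4.7-fold higher number from compound 2 to compound 4 (0.67 log units; beyond the scatter)). That step lies beyond the usual scatter, which shows that this position is sensitive to the choice of ring: 5-methyl-1,2-oxazol-3-yl, a five-membered aromatic ring with fewer heavy atoms, gives weaker inhibition than 4,6-dimethylpyrimidin-2-yl, although the counts of hydrogen-bond donors and acceptors stay the same. No measurement bears on why the number rises, so the step remains an observation without an explanation.

A single exchange cannot separate the effect of ring size from that of the ring oxygen or of the methyl groups, and a plain phenyl ring, a pyridin-2-yl group or an unsubstituted pyrimidin-2-yl group on the same nitrogen would help to tell these apart. Going by these compounds, it also remains open whether the same exchange would have a similar effect on a different core.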